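This account rests on a few compounds, and the source may have more. Where it says the series, first, only, none or still open, it means among the compounds named here.

Compound 1 `CC(C)(C)c1ccc(C(=O)N2CCC3(CC2)C(=O)N(CC(=O)N2CCCC(C(N)=O)C2)CN3c2ccccc2)cc1` gives 16900 nM in an assay on HEK293 cells for displacement of a labelled ligand from NPC1-like intracellular cholesterol transporter 1 (Homo sapiens); on this read-out lower numbers stand for stronger inhibition and higher numbers for weaker inhibition.
Compound 2 `CC(C)(C)c1ccc(C(=O)N2CCC3(CC2)C(=O)N(CC(=O)N2CCCC(O)C2)CN3c2ccccc2)cc1` gives 12200 nM in this assay.
Compound 3 `CCOC(=O)C1CCCN(C(=O)CN2CN(c3ccccc3)C3(CCN(C(=O)c4ccc(C(C)(C)C)cc4)CC3)C2=O)C1` gives 8200 nM in this assay.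

Compound 3 has the lowest of the three numbers: the nearest is compound 2, with a 1.5-fold lower number from compound 2 to compound 3 (0.17 log units; within the scatter), and the furthest is compound 1, with a 2.1-fold lower number from compound 1 to compound 3 (0.31 log units; beyond the scatter). Compound 4 `CC(C)(C)OC(=O)NCC1CCCN(C(=O)CN2CN(c3ccccc3)C3(CCN(C(=O)c4ccc(C(C)(C)C)cc4)CC3)C2=O)C1` differs from compound 3 in one place: ((tert-butoxycarbonyl)amino)methyl in place of ethoxycarbonyl on a saturated ring carbon. Within the data shown here, the steps that bear on this are the earlier swaps on the same saturated ring carbon, a 1.4-fold lower number from compound 1 to compound 2 (0.14 log units; within the scatter) and a 1.5-fold lower number from compound 2 to compound 3 (0.17 log units; within the scatter), both small. On that basis the new group is expected to move this assay little, with no step beyond the scatter, so the estimate means a 1.0-fold lower number from compound 3 to compound 4 (0.01 log units; within the scatter). Compound 4 is therefore expected to give about 8000 nM in this assay, with a range from 3500 nM to 18000 nM.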

Compound 4, half-maximal inhibitory concentration: 9500 nM
Compound 4: middle estimate off by 1.2-fold (0.07 log units), on the low side, and the stated range covers the measured number.
By their numbers in this assay, from the lowest: compounds 3, 4, 2 and 1 (each within the scatter of the next, the first and the last beyond it).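

On this saturated ring carbon, ((tert-butoxycarbonyl)amino)methyl, with 9 heavy atoms against 5 in ethoxycarbonyl, gives a 1.2-fold higher number from compound 3 to compound 4 (0.06 log units; within the scatter) and a 1.3-fold lower number from compound 2 to compound 4 (0.11 log units; within the scatter) as well as a 1.8-fold lower number from compound 1 to compound 4 (0.25 log units; within the scatter) in this assay so this larger group, which also brings a hydrogen-bond donor, stays within the scatter of all three earlier compounds. Nothing measured here explains why these groups read so alike. Still open is whether a free aminomethyl group or a carboxylic acid on this carbon would stand beyond the scatter of these compounds.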